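The source may hold more compounds than are shown below. What is called first, only, known or untested is meant among the compounds shown, and "the series" means these compounds.

Compound 1 `N#Cc1ccc(Nc2nccc(Oc3ccc(-c4ccc(C#N)cc4)cc3Cl)n2)cc1`: in a functional assay on MT4 cells (Homo sapiens) for cytotoxicity, read by MTT assay, with a stated time of 5 days (on this read-out higher numbers stand for lower toxicity in this test and lower numbers for higher toxicity in this test), compound 1 gives > 295000 nM, a limit of the assay.
Compound 2 `Cc1cc(-c2ccc(Oc3ccnc(Nc4ccc(C#N)cc4)n3)c(F)c2)ccc1C#N`: in this assay compound 2 gives > 296000 nM, again only a limit.
Compound 3 `Cc1cc(-c2ccc(C#N)cc2)ccc1Nc1ccnc(Nc2ccc(C#N)cc2)n1`: in this assay compound 3 gives 9200 nM.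

Compound 2 thus stands at a limit, as does compound 1 (the limit of > 296000 nM in this assay, at which 1 of the 3 values shown sits, (the limit of > 295000 nM in this assay, at which 1 of the 3 values shown sits)); compound 3 alone returns a number. Compound 4 `N#Cc1ccc(Nc2nccc(Oc3ccc(-c4ccc(C#N)cc4F)cc3F)n2)cc1` differs from compound 2 by 4-cyano-2-fluorophenyl in place of 4-cyano-3-methylphenyl on an aromatic carbon. Among the compounds with values here, no measured pair spans a change of this kind, so there is nothing to rest a directional call on. Compound 4 is expected to stay at the limit, and the step from compound 2 to compound 4 is estimated at an at least 1.0-fold lower number from compound 2 to compound 4 (0.00 log units; that floor lies within the scatter), none beyond the scatter. For compound 4 the estimate is 290000 nM, between 100000 nM and 400000 nM.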

Compound 4, half-maximal cytotoxic concentration: > 294000 nM
Compound 4: a limit, no number (the forecaster's own chance of this, stated with the estimate: 80%); middle value at least 1.0-fold (0.00 log units) away from the limit.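

In this assay compound 4 gives > 294000 nM, a limit, and compound 2 also stands at a limit, so no step can be read between them. As far as these compounds go, how 4-cyano-2-fluorophenyl in place of 4-cyano-3-methylphenyl shifts the half-maximal cytotoxic concentration remains open.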